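This account rests on a few compounds, and the source may have more. Where it says the series, first, only, none or still open, it means among the compounds named here.

Compound 1 `C=C(CC)C(=O)c1ccc(OCC(=O)O)cc1C` and compound 2 `C=C(C)C(=O)c1ccc(OCC(=O)O)cc1C` share one core, while compound 3 `C=C(CC)C(=O)c1ccc(OC(C)C(=O)O)cc1Cl` and compound 4 `C=C(C)C(=O)c1ccc(OC(C)C(=O)O)cc1Cl` share another; the difference between the two cores is not broken down here. In a functional assay on HL-60 cells (Homo sapiens) for antiproliferative activity, with a stated time of 72 h (on this read-out lower numbers stand for stronger inhibition of growth and higher numbers for weaker inhibition of growth), compound 1 gives only a limit of the assay, > 60000 nM. Compound 2 likewise gives only a limit, > 60000 nM. The change from compound 1 to compound 2, (hydrogen in place of methyl on a saturated chain carbon bound to a double-bonded chain carbon), thus makes a step that the two limits leave unreadable from compound 1 to compound 2. Compound 3 also gives only a limit, > 60000 nM. All three measured values sit at the limit of > 60000 nM in this assay, at which 3 of the 3 values shown sit. The same change, (hydrogen in place of methyl on a saturated chain carbon bound to a double-bonded chain carbon), leads from compound 3 to compound 4. Due to the limit of > 60000 nM in this assay, at which 3 of the 3 values shown sit, the step is expected to be a step that the limit leaves unreadable from compound 3 to compound 4. Compound 4 is therefore expected to give about 100000 nM, between 40000 nM and 300000 nM, most probably again only a limit.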

Compound 4, concentration for 50% growth inhibition: > 60000 nM
Compound 4: no number, only a limit; the forecaster's own chance of this, stated with the estimate: 85%; the middle value is on the limit's open side.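

Compound 3 and compound 4 each give only a limit, so no step can be read between them: the limit of > 60000 nM in this assay, at which 4 of the 4 values shown sit.

The compounds shown leave open whether hydrogen in place of methyl changes growth inhibition in this assay at all.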